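The source may report more compounds than this note shows. Statements on the series, on what has been measured and on what is new or still open speak of the compounds shown alone.

Measured so far:

Compound 1, `CN1CCN(c2ccc(Nc3nc(-c4cccc(NC(=O)c5ccc(C(C)(C)C)cc5)c4)sc3C(N)=O)cc2)CC1`: 80.1%
Compound 2, `CN1CCN(c2ccc(Nc3nc(-c4cccc(NC(=O)c5ccccc5F)c4)sc3C(N)=O)cc2)CC1`: 95.5%
Compound 3, `CN1CCN(c2ccc(Nc3nc(-c4cccc(NC(=O)c5ccc(Cl)cc5)c4)sc3C(N)=O)cc2)CC1`: 99%

These three share one core and differ only in the ring attached to the carbonyl carbon of the amide. In a functional assay on Ramos cells (Homo sapiens) for antiproliferative activity, read by CCK-8 assay, with a stated time of 72 h, tested at 40 uM (a higher number here means more inhibition at the concentration tested (going by the name of the read-out), a lower number less inhibition), compound 3 gives the highest of the three numbers; compound 2 sits close to it, the gap of a number 3.5 percentage points higher from compound 2 to compound 3 (within the scatter) lying within the scatter, while compound 1 lies clearly lower, by a number 18.9 percentage points higher from compound 1 to compound 3 (beyond the scatter).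

Compound 4, `CN1CCN(c2ccc(Nc3nc(-c4cccc(NC(=O)c5ccc(C(F)(F)F)cn5)c4)sc3C(N)=O)cc2)CC1`, is the next step from compound 3: 5-(trifluoromethyl)pyridin-2-yl in place of 4-chlorophenyl on a carbonyl carbon.

The steps measured so far all concern that same ring on the carbonyl carbon. Replacing the tert-butyl-bearing ring gave a modest rise in both a number 15.4 percentage points higher from compound 1 to compound 2 (beyond the scatter) and a number 18.9 percentage points higher from compound 1 to compound 3 (beyond the scatter), whereas swapping one halogen-bearing ring for another, a number 3.5 percentage points higher from compound 2 to compound 3 (within the scatter), changed nothing beyond the scatter. Among the measured compounds shown here, no measured step introduces a ring with a nitrogen atom or a trifluoromethyl group, so the new change is not directly covered. Compound 3 already stands at 99%, leaving little room upward. The expected step is therefore estimated as a number 9 percentage points lower from compound 3 to compound 4 (within the scatter). Compound 4 is therefore estimated at 90%, with a likely range from 70% to 99%.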

Compound 4, a percentage reported as inhibition, at one concentration (the size of the read-out at that concentration, not a potency): 96.6%
Compound 4: middle estimate off by 6.6 percentage points, on the low side, within the range that was stated.
By their numbers in this assay, from the lowest: compound 1; then compounds 2, 4 and 3 (each within the scatter of the next).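

In this assay, a ring holding a nitrogen atom and a trifluoromethyl group stands on the carbonyl carbon without a change beyond the scatter: 5-(trifluoromethyl)pyridin-2-yl in place of 4-chlorophenyl gives a number 2.4 percentage points lower from compound 3 to compound 4 (within the scatter), and in place of 2-fluorophenyl it gives a number 1.1 percentage points higher from compound 2 to compound 4 (within the scatter). In place of 4-(tert-butyl)phenyl, the same ring gives a number 16.5 percentage points higher from compound 1 to compound 4 (beyond the scatter), so the 4-(tert-butyl)phenyl ring of compound 1 is now set apart from three other rings, which read alike at this one concentration even though they differ in their ring atoms and substituents. Nothing available here explains why these three rings read alike.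

Going by these compounds, the ring nitrogen and the trifluoromethyl group enter together, so their separate contributions stay unknown, and a single concentration gives no potency that could separate compound 2, compound 3 and compound 4. On these data alone, it also remains open how this position would respond to a ring bearing an amine or a carboxylic acid, or to a longer alkyl chain in place of the ring.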